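Pendant ring substituent on a biaryl imidazoline series

The source may report more compounds than this note shows. Statements on the series, on what has been measured and on what is new or still open speak of the compounds shown alone.

Three compounds of the series have numbers. Compound 1 `CC(Oc1ccccc1-c1ccc([N+](=O)[O-])cc1)C1=NCCN1` gives in an assay on CHO cells for displacement of a labelled ligand from Alpha-2B adrenergic receptor (Homo sapiens) (a lower number here means a stronger inhibitor, a higher number a weaker inhibitor), a value of 501 nM. Compound 2 `CC(Oc1ccccc1-c1ccccc1O)C1=NCCN1` gives 1000 nM. Compound 3 `Cc1ccccc1-c1ccccc1OC(C)C1=NCCN1` gives 832 nM. Among the measured compounds shown here, the one single-point step so far is a 1.2-fold lower number from compound 2 to compound 3 (0.08 log units; within the scatter). On the numbers shown, compound 3 sits closest to compound 2 and furthest from compound 1, yet both gaps are within the scatter, so no ranking of the three can be drawn.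

The next compound is compound 4 `CC(Oc1ccccc1-c1ccc(O)cc1)C1=NCCN1`. The change from compound 3 is 4-hydroxyphenyl in place of 2-methylphenyl on an aromatic carbon. For the measured compounds named here, only one measured step bears on it: the step from compound 2 to compound 3 also swaps a hydroxy and a methyl on the pendant aromatic ring, and it stayed within the scatter. The hydroxy now enters at the position of the nitro of compound 1, whose number is within the scatter of compound 3 as well. The data thus contain no exchange on this ring that moved the number beyond the scatter. The expected step is a 1.0-fold lower number from compound 3 to compound 4 (0.02 log units; within the scatter), that is, none beyond the scatter. Compound 4 is therefore estimated at 800 nM, with a range from 300 nM to 2000 nM.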

Compound 4, inhibition constant: 813 nM
Compound 4: middle estimate off by 1.0-fold (0.01 log units), on the low side; low and high end bracket the measured number.
By their numbers in this assay, from the lowest: compounds 1, 4, 3 and 2 (each within the scatter of the next).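

Hydroxy position on the pendant ring can now be read for the first time: 4-hydroxyphenyl in place of 2-hydroxyphenyl gives a 1.2-fold lower number from compound 2 to compound 4 (0.09 log units; within the scatter) in this assay, so this shift of the hydroxy does not move the number beyond the scatter. Two further exchanges agree, with hydroxy in place of nitro giving a 1.6-fold higher number from compound 1 to compound 4 (0.21 log units; within the scatter) and 4-hydroxyphenyl in place of 2-methylphenyl giving a 1.0-fold lower number from compound 3 to compound 4 (0.01 log units; within the scatter), even though the entering group brings a hydrogen-bond donor and acceptor that 2-methylphenyl lacks. No supporting data on hand bear on this result.

Open, going by these compounds, is whether any pendant group moves the number beyond the scatter at all, since hydroxy, nitro and methyl have so far all given values within the scatter of one another, and an amine, a carboxylic acid or a longer chain such as butoxy in the place of the hydroxy of compound 4 would test that. Also open is whether the number answers more to changes on the shared core than to changes on this ring, as every compound shown keeps that core unchanged.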